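Adding a fluorobenzylsulfanyl group to compound 1

This account rests on a few compounds, and the source may have more. Where it says the series, first, only, none or still open, it means among the compounds named here.

Compound 1 `Cc1cc(Nc2cc(-c3ccccc3)[nH]n2)n2ncnc2n1` is the smallest member of this set. In a functional assay on MGC-803 cells (Homo sapiens) for inhibition, read by MTT assay, with a stated time of 72 h (a lower number here means a stronger inhibitor, a higher number a weaker inhibitor), compound 1 gives 21700 nM, the highest number among the three measured compounds. Compound 2 `CCCCCc1c(C)nc2nc(SCc3ccc(Cl)cc3)nn2c1Nc1cc(-c2ccccc2)[nH]n1` gives 7140 nM and compound 3 `Cc1cc(Nc2cc(-c3ccc(Cl)cc3)[nH]n2)n2nc(SCc3ccc(Br)cc3)nc2n1` gives 2780 nM; both carry a larger substituent in place of that hydrogen and both lie beyond the scatter below compound 1. Compound 4 `Cc1cc(Nc2cc(-c3ccccc3)[nH]n2)n2nc(SCc3ccc(F)cc3)nc2n1` differs from compound 1 by (4-fluorobenzyl)sulfanyl in place of hydrogen on an aromatic carbon, on an aromatic carbon of a five-membered aromatic ring with 3 nitrogen, between two ring nitrogen atoms. Within the data shown here, no measured pair isolates this exact change. Because compound 2 reads 7140 nM and compound 3 reads 2780 nM, a drop beyond the scatter is expected for compound 4, estimated as a 3.9-fold lower number from compound 1 to compound 4 (0.60 log units; beyond the scatter). Compound 4 is accordingly estimated at 5500 nM, within a range from 1800 nM to 16000 nM.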

Compound 4, half-maximal inhibitory concentration: 3270 nM
Estimate against measurement, compound 4: 1.7-fold (0.23 log units) above; measured number inside the range.
By their numbers in this assay, from the lowest: compounds 3 and 4 (each within the scatter of the next); then compound 2; then compound 1.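

In this assay, among these compounds, the (4-fluorobenzyl)sulfanyl group, placed on the aromatic carbon between two ring nitrogen atoms, gives a 6.6-fold lower number from compound 1 to compound 4 (0.82 log units; beyond the scatter) and is the first single-place change that can be read. On the core of compound 1, hydrogen at this position is therefore not required for inhibition, and a substituted benzylsulfanyl group is accepted there. No available evidence bears on the origin of this step.

The compounds shown leave open how an amine or a methylsulfanyl group on the same carbon would read. They also leave open whether the fluorine or the benzene ring of the entering group contributes to the step.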